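This account rests on a few compounds, and the source may have more. Where it says the series, first, only, none or still open, it means among the compounds named here.

Compound 1 `CCCCCCc1cn([C@H]2C[C@H](O)[C@@H](CO)O2)c(=O)[nH]c1=O` gives 195 ug/mL in a functional assay on L1210 cells (Mus musculus); on this read-out lower numbers stand for stronger inhibition and higher numbers for weaker inhibition. Compound 2 `CCCCc1cn([C@H]2C[C@H](O)[C@@H](CO)O2)c(=O)[nH]c1=O` stands at a limit of this assay, > 500 ug/mL. Within the data shown here, the only measured step, an at least 2.5-fold higher number from compound 1 to compound 2 (0.40 log units; beyond the scatter), is thus bounded by the limit of > 500 ug/mL in this assay, at which 1 of the 2 values shown sits, and its true size is unknown. Compound 3 `CCCCCc1cn([C@H]2C[C@H](O)[C@@H](CO)O2)c(=O)[nH]c1=O` differs from compound 2 by methyl in place of hydrogen on a saturated chain carbon, four bonds along the chain from an aromatic carbon, so its chain lies between those of compound 2 and compound 1. A partial return toward compound 1 is expected, as step an at least 1.4-fold lower number from compound 2 to compound 3 (0.15 log units; that floor lies within the scatter) in this assay. For compound 3 the estimate is 350 ug/mL, within 150 ug/mL to 900 ug/mL, with a fair chance that only a limit is reported again.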

Compound 3, concentration for 50% inhibition: 477 ug/mL
The estimate for compound 3 lay 1.4-fold (0.13 log units) below the measured number, within the range that was stated.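

In this assay, hydrogen in place of methyl, five bonds along the chain from an aromatic carbon, gives a 2.4-fold higher number from compound 1 to compound 3 (0.39 log units; beyond the scatter), so a shortening of the chain from compound 1 now has a size not tied to a limit. The other step, an at least 1.0-fold lower number from compound 2 to compound 3 (0.02 log units; that floor lies within the scatter), gives only a floor within the scatter, and its true size cannot be read: the limit of > 500 ug/mL in this assay, at which 1 of the 3 values shown sits.

Going by these compounds, whether a longer chain than that of compound 1 lowers the number further remains open. So does the effect of an amine or a carboxylic acid at the chain end.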